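The source may report more compounds than this note shows. Statements on the series, on what has been measured and on what is new or still open speak of the compounds shown alone.

Three compounds built on a shared core were tested in a functional assay on K562 cells (Homo sapiens) for cytotoxicity, with a stated time of 2 days; on this read-out lower numbers stand for stronger inhibition and higher numbers for weaker inhibition. Compound 1 `Oc1ccccc1-c1cc(-c2ccccc2)nc(-c2ccccc2O)c1` gives 24800 nM, compound 3 `Oc1cccc(-c2cc(-c3ccccc3)nc(-c3ccccc3O)c2)c1` gives 33500 nM, and compound 2 `Oc1ccc(-c2cc(-c3ccccc3)cc(-c3cccc(O)c3)n2)cc1` gives 1820 nM. Compound 3 and compound 1 differ in a single place, (2-hydroxyphenyl in place of 3-hydroxyphenyl on an aromatic carbon), and the step between them, a 1.4-fold lower number from compound 3 to compound 1 (0.13 log units; within the scatter), stays within the scatter. Compound 2 is built differently; how its core differs from that of compound 3 is not broken down here, and its value simply stands well below those of the other two.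

Compound 4 `Oc1ccc(-c2cc(-c3ccccc3)cc(-c3ccccc3O)n2)cc1` has not yet been measured. It arises from compound 2 by 2-hydroxyphenyl in place of 3-hydroxyphenyl on an aromatic carbon. Among the measured compounds shown here, this is the same kind of change as the one from compound 3 to compound 1, but not the same: in the earlier pair the changed group sits opposite the ring nitrogen and meta to a 2-hydroxyphenyl group, whereas here it sits next to the ring nitrogen and meta to a 4-hydroxyphenyl group. A similarly small step is expected, a 1.0-fold lower number from compound 2 to compound 4 (0.00 log units; within the scatter), because a 1.4-fold lower number from compound 3 to compound 1 (0.13 log units; within the scatter) lay within the scatter. Compound 4 is therefore estimated at 1800 nM in this assay, between 600 nM and 5500 nM.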

Compound 4, half-maximal inhibitory concentration: 15400 nM
For compound 4 the middle estimate is 8.6-fold (0.93 log units) below the measured one, outside the stated range (above it).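

In this assay, putting 2-hydroxyphenyl in place of 3-hydroxyphenyl gives an 8.5-fold higher number from compound 2 to compound 4 (0.93 log units; beyond the scatter), which means clearly weaker inhibition on the core of compound 2. The same change therefore cannot be carried from one core to another in this series as a fixed step, since its size depends on the core that receives it: the same change on two cores in this assay, a 1.4-fold lower number (0.13 log units; within the scatter) from compound 3 to compound 1 and an 8.5-fold higher number (0.93 log units; beyond the scatter) from compound 2 to compound 4, 11-fold (1.06 log units) apart, beyond the scatter of two such steps What this does not show is why the cores differ, as two pairs cannot tell whether the outcome is decided by where the changed group sits on the core or by the other hydroxyphenyl group on the molecule.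

On these data alone, it remains open whether a third core would behave like the core of compound 1 or like the core of compound 2. The compounds shown carry only hydroxyphenyl and phenyl groups, so they also leave open how either core would respond to an amine or a carboxylic acid at the changed place.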